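A few compounds are considered here, and "the series" means these few. Any claim that something is new, unique, unknown or untested is made for them only; others in the source may bear on it.

Measured in a functional assay on HGC-27 cells (Homo sapiens) for cytotoxicity, read by MTT assay, with a stated time of 72 h (on this read-out lower numbers stand for stronger inhibition and higher numbers for weaker inhibition), so far:
compound 1 `O=C1C=CCC/C1=C\C=C\c1ccc(F)cc1` - 2300 nM
compound 2 `O=C1C=CCC/C1=C\C=C\c1ccc(Cl)cc1` - 4800 nM

Compound 2, at 4800 nM, holds the higher of the two numbers in this assay and so the weaker inhibition. Compound 3 `O=C1C=CCC/C1=C\C=C\c1ccc([N+](=O)[O-])cc1` carries nitro in place of chloro on an aromatic carbon, para to a large group: nitro in place of chloro on an aromatic carbon. Among the measured compounds shown here, the only measured step at this place is modest, a 2.1-fold higher number from compound 1 to compound 2 (0.32 log units; beyond the scatter), and it exchanges chloro and fluoro, so it bears only indirectly. For the measured compounds named here, no nitro compound has been measured. A step of no greater size is expected, slightly towards a lower number and within the scatter: a 1.4-fold lower number from compound 2 to compound 3 (0.14 log units; within the scatter) is the estimated step. For compound 3 the estimated value is 3500 nM, with an expected range from 1200 nM to 10000 nM.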

Compound 3, half-maximal inhibitory concentration: 5200 nM
For compound 3 the middle estimate is 1.5-fold (0.17 log units) below the measured one; low and high end bracket the measured number.
By their numbers in this assay, from the lowest: compound 1; then compounds 2 and 3 (each within the scatter of the next).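

In this assay, nitro in place of chloro on an aromatic carbon, para to a large group, gives a 1.1-fold higher number from compound 2 to compound 3 (0.03 log units; within the scatter) and so leaves the read-out within the scatter. Set against fluoro, the same group gives a 2.3-fold higher number from compound 1 to compound 3 (0.35 log units; beyond the scatter) and thus stands with chloro, leaving compound 1 alone at the low end of the three. No measurement available here bears on why fluoro stands apart. As far as these compounds go, whether an amine, a methoxy group or a carboxylic acid at this place would read with fluoro or with chloro and nitro remains open.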